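Methoxy in place of hydrogen: two pairs compared

This account rests on a few compounds, and the source may have more. Where it says the series, first, only, none or still open, it means among the compounds named here.

Measured compounds in a functional assay on HeLa cells (Homo sapiens) for antiproliferative activity, with a stated time of 48 h; a higher number here means a weaker inhibitor, a lower number a stronger inhibitor:
compound 1 `C=C(Br)C(=O)Nc1ccc(/C=C/C(=O)c2ccccc2)cc1` — 3900 nM
compound 2 `C=C(Br)C(=O)Nc1ccc(/C=C/C(=O)c2cccc(OC)c2)cc1` — 700 nM
compound 3 `C=C(Br)C(=O)Nc1ccc(C(=O)/C=C/c2ccccc2)cc1` — 960 nM

Compound 4 `C=C(Br)C(=O)Nc1ccc(C(=O)/C=C/c2ccc(OC)cc2)cc1` has not yet been measured in this assay. Compound 1 and compound 3 have the same atoms joined differently; the difference between the two cores is not broken down here. Compound 3 stands second highest of the three numbers: its value and that of compound 2 lie within the usual scatter of each other, while compound 1 gives a higher number than compound 3 beyond the scatter.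

From compound 1 to compound 2 the change is methoxy in place of hydrogen on an aromatic carbon and it produced a 5.6-fold lower number from compound 1 to compound 2 (0.75 log units; beyond the scatter). From compound 3 to compound 4 the change is methoxy in place of hydrogen on an aromatic carbon. These are the same kind of change, not the same: in compound 2 the methoxy sits meta to a large group, in compound 4 para to a large group, and the cores differ as noted. For the measured compounds named here, only one measured instance of this change exists, on another core and another place. For compound 4 the expected step is a 2.4-fold lower number from compound 3 to compound 4 (0.38 log units; beyond the scatter), held smaller than a 5.6-fold lower number from compound 1 to compound 2 (0.75 log units; beyond the scatter). Compound 4 is therefore estimated at 400 nM, within 150 nM to 1200 nM.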

Compound 4, half-maximal inhibitory concentration: 310 nM
Compound 4: the middle estimate sits 1.3-fold (0.11 log units) above what was measured, and the stated range covers the measured number.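

In this assay methoxy in place of hydrogen on an aromatic carbon gave a 3.1-fold lower number from compound 3 to compound 4 (0.49 log units; beyond the scatter) and so moved the number the same way as on the earlier core. Set side by side, the two steps agree in direction and do not differ in size beyond the scatter: the same change on two cores in this assay, a 5.6-fold lower number (0.75 log units; beyond the scatter) from compound 1 to compound 2 and a 3.1-fold lower number (0.49 log units; beyond the scatter) from compound 3 to compound 4, 1.8-fold (0.26 log units) apart, within the scatter of two such steps.
This supports carrying the change between these two cores, but it rests on only two pairs with the methoxy at a different place in each, so the effect of place is not separated from that of core, and nothing is shown for any further core.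

The compounds shown leave open whether the lower number is particular to methoxy or would also follow from another group at the same place, such as hydroxy, fluorine or a longer ethoxy chain. Also open, as far as these compounds go, is what each core gives with the methoxy at the place it holds on the other core.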